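The source may hold more compounds than are shown below. What is called first, only, known or untested is meant among the compounds shown, and "the series" means these compounds.

Compound 1 `COc1ccc2c(=O)c(/C=C/C(=O)Nc3cccc(Cl)c3)coc2c1` gives 11900 nM in a functional assay on HeLa cells (Homo sapiens) for inhibition, read by MTT assay, with a stated time of 48 h; a higher number here means a weaker inhibitor, a lower number a stronger inhibitor. Compound 2 `COc1ccc2c(=O)c(/C=C/C(=O)Nc3ccc(C)cc3)coc2c1` gives 24100 nM in this assay, and the step of a 2.0-fold higher number from compound 1 to compound 2 (0.31 log units; beyond the scatter) is a modest weakening. Compound 3 `COc1ccc(CNC(=O)/C=C/c2coc3cc(OC)ccc3c2=O)cc1` reports only a limit in this assay, namely > 100000 nM, so its position is known only as the weakest end of the set shown, without a number. The steps of an at least 8.4-fold higher number from compound 1 to compound 3 (0.92 log units; beyond the scatter) and an at least 4.1-fold higher number from compound 2 to compound 3 (0.61 log units; beyond the scatter) both show that replacing the anilide-type groups by 4-methoxybenzyl costs at least a modest amount, and for compound 3 the weakening is only bounded, not measured, because of the limit of > 100000 nM in this assay, at which 1 of the 3 values shown sits.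

Compound 4 `COc1ccc2c(=O)c(/C=C/C(=O)NCc3ccc(F)cc3)coc2c1` differs from compound 3 by fluoro in place of methoxy on an aromatic carbon. Within the data shown here, no measured step among compounds 1, 2 and 3 changes a substituent on a benzyl group; the only substituent swap measured, a 2.0-fold higher number from compound 1 to compound 2 (0.31 log units; beyond the scatter), sits on an aryl amide and is modest. Compound 4 keeps the benzyl arrangement that took compound 3 past the limit, so compound 4 is expected to stay at or close to that limit, with the step that the limit leaves unreadable from compound 3 to compound 4 expected to lie within the scatter. Compound 4 is therefore estimated at 150000 nM in this assay, between 50000 nM and 500000 nM.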

Compound 4, half-maximal inhibitory concentration: > 100000 nM
Compound 4 was reported as a limit; the forecaster's own chance of this, stated with the estimate: 70%; the middle value does not contradict the limit.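

With 4-fluorobenzyl on the amide nitrogen, as with 4-methoxybenzyl, the compound falls at the limit of this assay, so reaching that limit is not peculiar to the methoxy group of compound 3. Measured against the two anilide-type compounds, the loss appears again, as an at least 4.1-fold higher number from compound 2 to compound 4 (0.61 log units; beyond the scatter) and as an at least 8.4-fold higher number from compound 1 to compound 4 (0.92 log units; beyond the scatter), and both sizes are only lower bounds. The step from compound 3 to compound 4 cannot be read, and fluoro and methoxy on this aromatic carbon, para to a large group, cannot be placed in any order, since neither compound has a measured number and both stop at the same boundary: the limit of > 100000 nM in this assay, at which 2 of the 4 values shown sit.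

The compounds shown leave open whether any benzyl amide on this core can give a measurable number in this assay, which a 3-chlorobenzyl group, or a benzyl group carrying an amine or a carboxylic acid, would help to settle. They also leave open whether a longer chain, such as 2-phenylethyl, on the amide nitrogen would stay at the limit as well.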